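The compounds below may be only part of what the source reports. "The series", "measured", "known", "first", "only" and "open" are said of these compounds alone.

Measured compounds:
compound 1 `O=C(O)C#Cc1ccc(Cn2cccn2)cc1OCCc1ccc2ccccc2c1` — in an assay on CHO cells for displacement of a labelled ligand from prostaglandin E2 receptor EP1 subtype (Mus musculus), read by scintillation counting (a higher number here means a weaker inhibitor, a lower number a stronger inhibitor), it reaches only the limit, > 10000 nM.
compound 2 `O=C(O)COc1ccc(Cn2cccn2)cc1OCCc1ccc2ccccc2c1` — in this assay it likewise reaches only the limit, > 10000 nM.

Both compounds share one core and differ in a single group on an aromatic carbon. Among the measured compounds shown here, the one step that connects them, a step that the two limits leave unreadable from compound 1 to compound 2, cannot be read, because both ends sit at the limit, as the limit of > 10000 nM in this assay, at which 2 of the 2 values shown sit, records. So compound 2 stands at the limit in this assay, and nothing measured here shows any binding at all.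

Compound 3 `O=C(O)CCCc1ccc(Cn2cccn2)cc1OCCc1ccc2ccccc2c1` carries the next change at the same position: 3-carboxypropyl in place of carboxymethoxy on an aromatic carbon. The chain grows by one heavy atom and loses the ether oxygen while keeping the acid.

For the measured compounds named here, no measured step bears on this change, since the only step available gives no readable size. With both neighbours at the limit, the expectation is a step that the limit leaves unreadable from compound 2 to compound 3 that stays within the scatter, so compound 3 is estimated at 20000 nM, with a range from 5000 nM to 100000 nM, most likely again reported only as a limit.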

Compound 3, inhibition constant: 4000 nM
For compound 3 the middle estimate is 5.0-fold (0.70 log units) above the measured one, and the stated range ends above it.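

This position is not indifferent to the group it carries: in this assay, the 3-carboxypropyl group gives an at least 2.5-fold lower number from compound 2 to compound 3 (0.39 log units; beyond the scatter), and set against the 2-carboxyethynyl group it gives an at least 2.5-fold lower number from compound 1 to compound 3 (0.39 log units; beyond the scatter). All three groups end in a carboxylic acid, so among these compounds the acid alone does not bring a readable value, and the chain that carries it makes the difference. Both steps give only a smallest possible size, not a true one, since compound 1 and compound 2 each stop at a limit of the assay: the limit of > 10000 nM in this assay, at which 2 of the 3 values shown sit.

The step from carboxymethoxy to 3-carboxypropyl removes the ether oxygen and adds a heavy atom in one move, and these compounds cannot show which of the two matters. Going by these compounds, it also remains open whether a longer chain ending in the carboxylic acid would lower the number further, and whether an amide in place of the acid on the 3-carboxypropyl chain would keep any of the binding.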